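The source may report more compounds than this note shows. Statements on the series, on what has been measured and on what is new or still open speak of the compounds shown alone.

Series notes. Compound 1 `Cc1cc(O)c(C(=O)/C=C/c2ccc(OCc3ccccc3)cc2)c(-c2ccccc2)c1C(=O)/C=C/c1ccc(OCc2ccccc2)cc1` serves as the reference point; in a functional assay on MCF7 cells (Homo sapiens) for cytotoxicity, read by MTT assay, with a stated time of 24 h (on this read-out higher numbers stand for weaker inhibition and lower numbers for stronger inhibition), compound 1 gives 10000 nM. Compound 3 `Cc1cc(O)c(C(=O)/C=C/c2ccc(OCc3ccccc3)cc2)c(-c2ccc(OCc3ccccc3)cc2)c1C(=O)/C=C/c1ccc(OCc2ccccc2)cc1` carries benzyloxy in place of hydrogen on an aromatic carbon; in this assay compound 3 gives 26000 nM. The step of a 2.6-fold higher number from compound 1 to compound 3 (0.41 log units; beyond the scatter) thus runs toward weaker inhibition. Compound 2 `COc1ccc(/C=C/C(=O)c2c(C)cc(O)c(C(=O)/C=C/c3ccc(OC)c(OC)c3)c2-c2ccccc2)cc1OC` rests on a different core, and the difference between the two cores is not broken down here. In this assay compound 2 is recorded as "not active" (no number reported), with no number reported. Compound 4 `COc1ccc(/C=C/C(=O)c2c(C)cc(O)c(C(=O)/C=C/c3ccc(OC)c(OC)c3)c2-c2ccc(OCc3ccccc3)cc2)cc1OC`, not yet measured, is compound 2 with benzyloxy in place of hydrogen on an aromatic carbon; this is the same change as that seen in compound 3, made on the core of compound 2. With compound 2 giving no number in this assay and the step of a 2.6-fold higher number from compound 1 to compound 3 (0.41 log units; beyond the scatter) pointing toward higher numbers, compound 4 is expected to remain weak or to fall outside the measured range altogether, so that a limit rather than a number is a real possibility. Should a number be returned, compound 4 is expected to sit at 50000 nM, estimated between 15000 nM and 150000 nM.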

Compound 4, half-maximal inhibitory concentration: 30000 nM
Compound 4: the middle estimate sits 1.7-fold (0.22 log units) above what was measured, within the range that was stated.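

Going by these compounds alone, compound 2 has no number in this assay, and no step to compound 4 can be read from it. The compounds shown leave open whether benzyloxy in place of hydrogen moves the number on the core of compound 2 as it does on the core of compound 1. No measurement shown here offers an explanation for the result of compound 4.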